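Indole acid series: chain shortening on the aminoalkyl side chain

This account rests on a few compounds, and the source may have more. Where it says the series, first, only, none or still open, it means among the compounds named here.

Measured compounds:
- compound 1 `NCCCCc1c[nH]c2ccc(C(=O)O)cc12`: "not active" (no number reported)
- compound 2 `ONCCCc1c[nH]c2ccc(F)cc12`: 21 nM

In an assay on isolated protein for inhibition of Myeloperoxidase (Homo sapiens), read by ELISA, with a stated time of 5 min (a higher number here means a weaker inhibitor, a lower number a stronger inhibitor), compound 1 is reported as "not active" (no number reported) with no number attached, so compound 1 has no single value to stand on. In this assay, among the compounds with values here, compound 2 gives 21 nM; compound 2 shares only part of its structure with compound 1 and no step between them is computed, so the two readings show only that one compound has a number and the other does not.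

Compound 3 `NCCCc1c[nH]c2ccc(C(=O)O)cc12` differs from compound 1 by amino in place of aminomethyl on a saturated chain carbon, three bonds along the chain from an aromatic carbon. Within the data shown here, no measured step of this kind is available in this assay. With compound 1 reading "not active" (no number reported), no movement beyond the scatter toward a strong inhibitor is expected for compound 3, and a report without a number is likely. Compound 3 is estimated at 30000 nM in this assay, expected range 3000 nM to 300000 nM.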

Compound 3, half-maximal inhibitory concentration: "not active" (no number reported)
The entry for compound 3 holds no number; no gap can be computed for the estimate.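

In this assay compound 3 gives "not active" (no number reported) and compound 1 gives "not active" (no number reported), so no step can be read between them. The compounds shown leave open what size, if any, the change from 4-aminobutyl to 3-aminopropyl has on this core. No evidence bears on this result.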